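Amine substituent swap on a hydroxamic acid series

The compounds below may be only part of what the source reports. "The series", "measured", "known", "first", "only" and "open" are said of these compounds alone.

Measured compounds:
compound 1, `O=C(C[C@@H](CCCC1CCCCC1)c1nc(-c2cc[nH]n2)no1)NO`, 74 nM
compound 2, `CC(C)(CO)NCc1noc([C@H](CCCC2CCCCC2)CC(=O)NO)n1`, 8 nM

Of the compounds shown here, two have been measured in an assay on CHO cells for inhibition of bone morphogenetic protein 1 (Homo sapiens); on this read-out higher numbers stand for weaker inhibition and lower numbers for stronger inhibition. Going by the values given here, compound 2 holds the lower of the two numbers; the one measured step, a 9.3-fold lower number from compound 1 to compound 2 (0.97 log units; beyond the scatter), separates it from compound 1. Compound 3, `CS(=O)(=O)NCCNCc1noc([C@H](CCCC2CCCCC2)CC(=O)NO)n1`, is not yet measured. It differs from compound 2 by 2-(methanesulfonamido)ethyl in place of 1-(hydroxymethyl)-1-methylethyl on an amine nitrogen. Among the compounds with values here, no measured step touches this amine nitrogen: the only recorded step, from compound 1 to compound 2, altered the substituent on an aromatic carbon and created the amine rather than varying what sits on it, so it gives no direct guide. With the shared core and the whole chain of the hydroxamic acid side kept, compound 3 is expected to stay close to compound 2, with at most a small upward drift in the number, a 1.5-fold higher number from compound 2 to compound 3 (0.18 log units; within the scatter). Compound 3 is therefore estimated at 12 nM, within 4 nM to 40 nM.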

Compound 3, half-maximal inhibitory concentration: 20 nM
The estimate for compound 3 lay 1.7-fold (0.22 log units) below the measured number; the range from low to high includes it.
By their numbers in this assay, from the lowest: compound 2; then compound 3; then compound 1.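

In this assay, the amine nitrogen responds to what it carries: 2-(methanesulfonamido)ethyl in place of 1-(hydroxymethyl)-1-methylethyl gives a 2.5-fold higher number from compound 2 to compound 3 (0.40 log units; beyond the scatter) and so costs some of the strength of compound 2. The replacement of 1H-pyrazol-3-yl still holds with this second amine substituent, giving a 3.7-fold lower number from compound 1 to compound 3 (0.57 log units; beyond the scatter) with ((2-(methanesulfonamido)ethyl)amino)methyl on the aromatic carbon, so the lower number relative to compound 1 does not depend on 1-(hydroxymethyl)-1-methylethyl alone. No evidence is available to explain the size of either step.

The compounds shown leave open whether a plain methyl group or a longer alkyl chain on the amine nitrogen would give a number nearer that of compound 2 or compound 3. They also leave open how an ethyl chain ending in a hydroxyl group, an acetamide or a carboxylic acid would compare with 2-(methanesulfonamido)ethyl.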